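Swapping chloro for cyano on the amide's phenyl ring

A few compounds are considered here, and "the series" means these few. Any claim that something is new, unique, unknown or untested is made for them only; others in the source may bear on it.

Measured so far in an assay on LtK cells with ATP-sensitive inward rectifier potassium channel 11 (Homo sapiens) as the target; a lower number here means that less compound is needed, a higher number that more compound is needed for the effect:
compound 1, `O=C(Nc1ccc(Cl)cc1)Nc1c(C(O)(C(F)(F)F)C(F)(F)F)ccc2ccccc12`, 276 nM
compound 2, `O=C(Nc1c(C(O)(C(F)(F)F)C(F)(F)F)ccc2ccccc12)c1cccc(Cl)c1`, 98 nM

Going by the values given here, compound 2 gives the lowest of these two numbers; the single step, a 2.8-fold lower number from compound 1 to compound 2 (0.45 log units; beyond the scatter), lies beyond the scatter. Compound 3, `N#Cc1cccc(C(=O)Nc2c(C(O)(C(F)(F)F)C(F)(F)F)ccc3ccccc23)c1`, differs from compound 2 by cyano in place of chloro on an aromatic carbon. Among the compounds with values here, no measured step touches this kind of exchange; the one step known alters a different part of the molecule, so it offers no direct guide. The expected step is therefore a 1.5-fold higher number from compound 2 to compound 3 (0.18 log units; within the scatter), with a wide range. Compound 3 is estimated at 150 nM, between 50 nM and 450 nM.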

Compound 3, half-maximal effective concentration: 12 nM
For compound 3 the middle estimate is 13-fold (1.10 log units) above the measured one; the whole stated range lies above it.
By their numbers in this assay, from the lowest: compound 3; then compound 2; then compound 1.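

With only chloro exchanged for cyano on the aromatic ring, an 8.2-fold lower number from compound 2 to compound 3 (0.91 log units; beyond the scatter) appears in this assay, so the group at this place clearly matters, which the earlier step, a replacement of the whole (4-chlorophenyl)amino group, could not show. Taken together, the changes give a 23-fold lower number from compound 1 to compound 3 (1.36 log units; beyond the scatter) and make the 3-cyanophenyl group the best of the three on the carbonyl carbon. No available finding explains why this exchange lowers the number. A carboxylic acid, an amine or a methoxy group at this place remains untested in the compounds shown. From the compounds shown here alone, whether cyano would give a similar step elsewhere on the ring also stays open.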